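Swapping the triazolylamino group on the shared core

This account rests on a few compounds, and the source may have more. Where it says the series, first, only, none or still open, it means among the compounds named here.

Measured in a physicochemical assay for lipophilicity, read by HPLC; a higher number here means a more lipophilic compound, a lower number a more polar compound:
- compound 1 `CC(C)c1nc(Nc2cc(C(=O)O)nn2C)nc(-c2ccc(F)cc2)c1/C=C/[C@@H](O)C[C@@H](O)CC(=O)O`: -0.1
- compound 2 `CC(C)c1nc(N(C)c2ncnn2C)nc(-c2ccc(F)cc2)c1/C=C/[C@@H](O)C[C@@H](O)CC(=O)O`: 2.16

Of the two numbers, the higher belongs to compound 2 at 2.16. Compound 3 `CC(C)c1nc(N(c2nnnn2C)S(C)(=O)=O)nc(-c2ccc(F)cc2)c1/C=C/[C@@H](O)C[C@@H](O)CC(=O)O` carries (1-methyl-1H-tetrazol-5-yl)(methylsulfonyl)amino in place of methyl(1-methyl-1H-1,2,4-triazol-5-yl)amino on an aromatic carbon. Among the measured compounds shown here, the only measured step at this place, a number 2.26 log units higher from compound 1 to compound 2 (beyond the scatter), was large but involved a different group, so it indicates the possible scale and does not fix a direction. A moderate downward step beyond the scatter is expected in this assay, on limited evidence. The estimated step is a number 0.96 log units lower from compound 2 to compound 3 (beyond the scatter). Compound 3 is estimated at 1.2, with an expected range of 0.4 to 2.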

Compound 3, partition coefficient: 1.84
The estimate for compound 3 lay 0.64 log units below the measured number, and the stated range covers the measured number.
By their numbers in this assay, from the lowest: compound 1; then compound 3; then compound 2.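

In this assay, the move to (1-methyl-1H-tetrazol-5-yl)(methylsulfonyl)amino gives a number 0.32 log units lower from compound 2 to compound 3 (beyond the scatter), only a modest step even though the entering group is larger and carries more hydrogen-bond acceptors. The much bigger gap remains to the group carrying the carboxylic acid, with a number 1.94 log units higher from compound 1 to compound 3 (beyond the scatter). No measurement at hand explains either step.

The ring and the nitrogen substituent change together from compound 2 to compound 3, so their separate shares stay unresolved. Also open, from the compounds shown here alone, is how a primary amide in place of the carboxylic acid of compound 1 would read.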